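The compounds below may be only part of what the source reports. "The series", "measured", "known", "first", "only" and "open" are said of these compounds alone.

Measured compounds:
compound 1, `Cc1c(C(=O)Nc2ccc(Oc3ncnc4[nH]cc(-c5ccccc5)c34)c(F)c2)c(=O)c2cc(Br)ccc2n1C` — 3120 nM
compound 2, `CCc1ccc2c(c1)c(=O)c(C(=O)Nc1ccc(Oc3ccnc(C(N)=O)c3)c(F)c1)c(C)n2C` — 4380 nM

Both numbers come from an assay on isolated protein for inhibition of tyrosine-protein kinase receptor UFO (Homo sapiens), read by FRET and Z'-LYTE, with a stated time of 1.5 h; on this read-out lower numbers stand for stronger inhibition and higher numbers for weaker inhibition. Compound 1 and compound 2 sit within the usual scatter of each other, so neither is set apart from the other on this read-out; the two together only fix the range in which this series has so far been found, and they differ in more than one place, so nothing is said about any single change between them.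

The step to the unmeasured compound 3, `CCCc1ccc2c(c1)c(=O)c(C(=O)Nc1ccc(Oc3ncnc4[nH]cc(-c5ccccc5)c34)c(F)c1)c(C)n2C`, keeps everything in compound 1 except one substituent: propyl in place of bromo on an aromatic carbon. Compound 2 already carries a short alkyl chain at the same kind of position, on a different pendant, and gives a number in the same range as the bromo compound 1, which offers no sign that an alkyl group there moves the read-out far. Among the compounds with values here, no measured pair isolates this change, so the expectation is a step of no more than the scatter, in either direction, for the step from compound 1 to compound 3, a 1.0-fold lower number from compound 1 to compound 3 (0.02 log units; within the scatter). On that basis compound 3 is estimated at 3000 nM, with a range from 1000 nM to 9000 nM.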

Compound 3, half-maximal inhibitory concentration: 61 nM
Estimate against measurement, compound 3: 49-fold (1.69 log units) above; the whole stated range lies above it.
By their numbers in this assay, from the lowest: compound 3; then compounds 1 and 2 (each within the scatter of the next).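

In this assay, within the data shown here, the exchange of bromo for propyl on this aromatic carbon gives a 51-fold lower number from compound 1 to compound 3 (1.71 log units; beyond the scatter), so this position is not indifferent to its substituent: a change confined to one group, with the rest of compound 1 kept, is enough to take the series out of the range that the earlier compounds had fixed. Neither group carries a hydrogen-bond donor or acceptor, a ring or a net charge, so the step arises without any change in these counts; what differs in the counts is bromine as a single heavy atom against the three carbons of propyl. This single pair shows the size of the step but not its origin, and nothing at hand gives a measured reason for it.

A single pair cannot tell whether the step comes from losing bromo or from gaining propyl, nor how the read-out follows chain length at this carbon. As far as these compounds go, a butyl chain, a methoxy group, an amine or a carboxylic acid in the same place would begin to separate these readings, and whether the step carries over to the pendant of compound 2 also stays open.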